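The source may hold more compounds than are shown below. What is called first, only, known or untested is meant among the compounds shown, and "the series" means these compounds.

Compound 1 `CC(C)(OCc1scnc1-c1ccc(Cl)cc1)C(=O)O`: 0.23
Compound 2 `CC(C)(OCc1ncsc1-c1ccc(Cl)cc1)C(=O)O`: 0.23
Compound 3 `CC(C)(OCc1coc(-c2ccc(Cl)cc2)n1)C(=O)O`: 0.23

These three compounds were compared in a physicochemical assay for lipophilicity; a higher number here means a more lipophilic compound, a lower number a more polar compound. Compound 3 reads 0.23 and stands level with compound 1 and compound 2, so the differences among their cores leave no visible gap at the digits shown. Compound 4 `Cc1oc(-c2ccc(Cl)cc2)nc1COC(C)(C)C(=O)O` differs from compound 3 in one place: methyl in place of hydrogen on an aromatic carbon. This puts methyl in place of hydrogen on an aromatic carbon, next to the ring oxygen. Going by the values given here, no measured pair here shows such a change, so the expectation rests on the structural change alone: a modest rise in this assay, slightly beyond the usual scatter. The expected change is a number 0.40 log units higher from compound 3 to compound 4 (beyond the scatter). The estimate for compound 4 is 0.63, within an expected range of 0.3 to 0.95.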

Compound 4, partition coefficient: 0.52
Estimate against measurement, compound 4: 0.11 log units above, and the stated range covers the measured number.
By their numbers in this assay, from the lowest: compounds 1, 2, 3 and 4 (each within the scatter of the next).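

In this assay, methyl in place of hydrogen on an aromatic carbon, next to the ring oxygen, gives a number 0.29 log units higher from compound 3 to compound 4 (within the scatter). Going by these compounds alone, this is the first step in the set that changes a single place, and it shows that methyl at this position leaves the reading within the usual spread of repeat measurements. Nothing available bears on the reason for this result. Still open, going by these compounds, is whether an ethyl chain or an amine on this same carbon would give a step beyond the scatter.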